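A few compounds are considered here, and "the series" means these few. Any claim that something is new, unique, unknown or untested is made for them only; others in the source may bear on it.

Measured in a functional assay on PC-3 cells (Homo sapiens), read by MTT assay, with a stated time of 48 h; a higher number here means a weaker inhibitor, a lower number a stronger inhibitor:
- Compound 1 `CCN(CC)CCNC(=O)c1ccc(C(CC)(CC)c2ccc(OCC(O)C(C)(C)C)c(C)c2)n1CC`: 220 nM
- Compound 2 `C#CCNC(=O)c1ccc(C(CC)(CC)c2ccc(OCC(O)C(C)(C)C)c(C)c2)n1CC`: 16200 nM

Compound 2, at 16200 nM, has the higher of the two numbers, making it the weaker inhibitor of this pair. Compound 3 `CCn1c(C(=O)N(CCC#N)CCC#N)ccc1C(CC)(CC)c1ccc(OCC(O)C(C)(C)C)c(C)c1` differs from it on the carbonyl carbon: a group of 9 heavy atoms (6 carbon, 3 nitrogen; no ring) in place of a group of 4 heavy atoms (3 carbon, 1 nitrogen; no ring), on a carbonyl carbon. Going by the values given here, the only measured step at this carbonyl, a 74-fold higher number from compound 1 to compound 2 (1.87 log units; beyond the scatter), is large, so changes here can matter. However, that step removes (diethylamino)methyl, which neither compound 2 nor compound 3 carries, and no measured compound holds the entering group. Only a small step of uncertain direction is therefore expected, and the estimated step is a 1.4-fold lower number from compound 2 to compound 3 (0.13 log units; within the scatter). For compound 3, the expected value is 12000 nM, with an estimated range of 3000 nM to 40000 nM.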

Compound 3, half-maximal inhibitory concentration: 7800 nM
Estimate against measurement, compound 3: 1.5-fold (0.19 log units) above; measured number inside the range.
By their numbers in this assay, from the lowest: compound 1; then compound 3; then compound 2.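

At this carbonyl carbon, a much larger group that lacks the hydrogen-bond donor of propargylamino does not weaken this assay: the change gives a 2.1-fold lower number from compound 2 to compound 3 (0.32 log units; beyond the scatter). Size alone does not recover the number of compound 1, since two groups of similar heavy-atom count still differ by a 35-fold higher number from compound 1 to compound 3 (1.55 log units; beyond the scatter). No measurement here explains either step. Still open, on these data alone, is whether a shorter dimethylamino chain would keep the low number of compound 1, and whether a plain diethylamide would behave like compound 3.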